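Dropping a Methyl Group: What to Expect for Compound 4

The compounds below may be only part of what the source reports. "The series", "measured", "known", "first", "only" and "open" are said of these compounds alone.

Compound 1 `Cc1ccc(N2CCN(CCNC(=O)c3cccnc3)CC2)cc1` gives 295 nM in a functional assay for antagonist activity at Adrenergic receptor alpha-1 (Rattus norvegicus); a higher number here means weaker binding, a lower number tighter binding.
Compound 2 `Cc1ccc(N2CCN(CCNC(=O)c3ccco3)CC2)cc1` gives 339 nM in this assay.
Compound 3 `Cc1ccc(N2CCN(CCNC(=O)c3cc4ccccc4o3)CC2)c(C)c1` gives 43.7 nM in this assay.

Compound 3 stands lowest of the three numbers, so it binds most tightly; the nearest is compound 1 and the furthest is compound 2, both beyond the scatter. Compound 4 `Cc1ccc(N2CCN(CCNC(=O)c3cc4ccccc4o3)CC2)cc1` differs from compound 3 by hydrogen in place of methyl on an aromatic carbon. Among the measured compounds shown here, the only measured single step, a 1.1-fold higher number from compound 1 to compound 2 (0.06 log units; within the scatter), concerns the group on the carbonyl carbon, not the methyl on the six-membered aromatic ring, so no measured step bears directly on this change. With nothing comparable to lean on, the expectation rests on compound 3 alone, and a modest weakening in this assay is estimated: the expected step is a 2.1-fold higher number from compound 3 to compound 4 (0.31 log units; beyond the scatter). Compound 4 is expected to give 90 nM, within 30 nM to 300 nM.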

Compound 4, dissociation constant: 120 nM
Compound 4: the middle estimate sits 1.3-fold (0.12 log units) below what was measured, and the stated range covers the measured number.
By their numbers in this assay, from the lowest: compound 3; then compound 4; then compounds 1 and 2 (each within the scatter of the next).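

In this assay, going from 2,4-dimethylphenyl to 4-methylphenyl costs binding beyond the scatter (a 2.7-fold higher number from compound 3 to compound 4 (0.44 log units; beyond the scatter)), so this one methyl, ortho to a large group, matters. With 4-methylphenyl held fixed, 1-benzofuran-2-yl on the carbonyl carbon also binds more tightly than either furan-2-yl (a 2.8-fold lower number from compound 2 to compound 4 (0.45 log units; beyond the scatter)) or pyridin-3-yl (a 2.5-fold lower number from compound 1 to compound 4 (0.39 log units; beyond the scatter)). Nothing measured here explains why either change has this effect.

Going by these compounds, whether a methoxy group or a chlorine atom in place of this methyl would bind as tightly remains open. So does whether the methyl gives a similar step with furan-2-yl or pyridin-3-yl on the carbonyl carbon.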